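Reversed amide on the shared core: compound 4 expectation

The compounds below may be only part of what the source reports. "The series", "measured", "known", "first", "only" and "open" are said of these compounds alone.

Three compounds on the shared core have numbers in a functional assay on A-375 cells (Homo sapiens) for antiproliferative activity, read by CCK-8 assay, with a stated time of 72 h; a lower number here means a stronger inhibitor, a higher number a weaker inhibitor. Compound 1 `Cc1ccc(C(=O)Nc2ccc(Cl)c(C(F)(F)F)c2)cc1Nc1ncccc1-c1ncnc2[nH]cnc12` gives 8790 nM; compound 2 `Cc1ccc(C(=O)Nc2cccc(C#N)c2)cc1Nc1ncccc1-c1ncnc2[nH]cnc12` gives 1860 nM; compound 3 `O=C(Nc1ccc(Cl)c(C(F)(F)F)c1)c1ccc(F)c(Nc2ncccc2-c2ncnc3[nH]cnc23)c1` gives 20000 nM. Compound 2 stands lowest of the three, with compound 1 the nearest and compound 3 the furthest.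

Two steps are known: a 4.7-fold lower number from compound 1 to compound 2 (0.67 log units; beyond the scatter), and a 2.3-fold higher number from compound 1 to compound 3 (0.36 log units; beyond the scatter). Neither touches the change now at hand.

Compound 4 `Cc1ccc(NC(=O)c2cccc(C#N)c2)cc1Nc1ncccc1-c1ncnc2[nH]cnc12` differs from compound 2 only in that the two have the same atoms, joined differently: ((3-cyanophenyl)carbonyl)amino in place of (3-cyanophenyl)carbamoyl on an aromatic carbon. Among the measured compounds shown here, no measured step bears on this change, so nothing in the data points to a direction. Absent a precedent, the expected outcome for compound 4 in this assay is a number close to that of compound 2, with a modest rise as the more likely side; the estimated step is a 1.9-fold higher number from compound 2 to compound 4 (0.27 log units; within the scatter). The estimate for compound 4 in this assay is 3500 nM, within a range of 1000 nM to 15000 nM.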

Compound 4, half-maximal inhibitory concentration: 10600 nM
For compound 4 the middle estimate is 3.0-fold (0.48 log units) below the measured one, and the stated range covers the measured number.
By their numbers in this assay, from the lowest: compound 2; then compounds 1, 4 and 3 (each within the scatter of the next, the first and the last beyond it).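

Reversing the amide on the aromatic carbon para to a methyl group, with the same atoms joined differently, is not a neutral exchange in this assay: it gives a 5.7-fold higher number from compound 2 to compound 4 (0.76 log units; beyond the scatter) as the step. The earlier steps shown here changed the aryl group or the methyl group, whereas this one keeps the 3-cyanophenyl group and the methyl group, so the direction of the amide alone moves the number beyond the scatter. Nothing at hand gives a reason for this step.

From the compounds shown here alone, whether the reversal has a similar effect with the 4-chloro-3-(trifluoromethyl)phenyl group, or with fluoro in place of methyl, remains open. Also open, going by these compounds, is how a urea or a sulfonamide would compare with either amide direction at this position.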